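Cytotoxicity notes: dimethylamino in place of methoxy

The source may report more compounds than this note shows. Statements on the series, on what has been measured and on what is new or still open speak of the compounds shown alone.

Measured so far:
compound 1 `CC1=C(C(=O)Nc2ccc(Cl)cc2)C(c2ccccc2)C(C(=O)Nc2ccc(Cl)cc2)=C(C)N1`: 15 ug/mL
compound 2 `COc1ccc(NC(=O)C2=C(C)NC(=O)NC2c2ccc(OC)cc2)cc1`: 158 ug/mL

In an ADME assay on Vero cells (Chlorocebus sabaeus) for cytotoxicity, read by sulforhodamine B assay, with a stated time of 3 days (a lower number here means that less compound is tolerated, a higher number that more compound is tolerated), compound 2 stands highest of the two numbers; compound 1 is the nearest and gives 15 ug/mL, a gap beyond the scatter. Compound 3 `COc1ccc(NC(=O)C2=C(C)NC(=O)NC2c2ccc(N(C)C)cc2)cc1` differs from compound 2 by dimethylamino in place of methoxy on an aromatic carbon. Among the measured compounds shown here, no step of this kind between measured compounds exists, so the change rests on no precedent here. A step no larger than the scatter is expected, leaning slightly lower. Compound 3 is expected to give 120 ug/mL, within 50 ug/mL to 260 ug/mL. The expected step is a 1.3-fold lower number from compound 2 to compound 3 (0.12 log units; within the scatter).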

Compound 3, half-maximal cytotoxic concentration: 236 ug/mL
The estimate for compound 3 lay 2.0-fold (0.29 log units) below the measured number; low and high end bracket the measured number.
By their numbers in this assay, from the lowest: compound 1; then compounds 2 and 3 (each within the scatter of the next).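

In this assay, dimethylamino in place of methoxy on an aromatic carbon, para to a large group, gives a 1.5-fold higher number from compound 2 to compound 3 (0.17 log units; within the scatter). Among the compounds shown here, this is the first single-place step, and it leaves compound 2 and compound 3 indistinguishable, so this position accepts the exchange with no readable effect on cytotoxicity. The data offer no measured basis for explaining this result. Still open, on these data alone, is whether a carboxylic acid, a primary amine or a longer alkoxy chain at this position would also stay within the scatter of compound 2.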